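Shortening the side chain of compound 1

A few compounds are considered here, and "the series" means these few. Any claim that something is new, unique, unknown or untested is made for them only; others in the source may bear on it.

Compound 1 `CC(C)CCn1ccc(N2CCC(c3ccccc3)CC2)c(C#N)c1=O`: 102 nM
Compound 2 `CC(C)CCn1ccc(N2CCCCC2)c(C#N)c1=O`: 31600 nM
Compound 3 `CC(C)CCn1ccc(N2CCN(c3ccccn3)CC2)c(C#N)c1=O`: 3090 nM

In a functional assay on CHO cells for positive allosteric modulation of metabotropic glutamate receptor 2 (Homo sapiens), with a stated time of 30 min (a higher number here means that more compound is needed for the effect, a lower number that less compound is needed), compound 1 gives the lowest number of the three. Compound 3 comes nearest, yet its number is already well beyond the scatter above that of compound 1, and compound 2 lies furthest away. For the measured compounds named here, the one step between compounds that differ in a single place is a 310-fold higher number from compound 1 to compound 2 (2.49 log units; beyond the scatter), where hydrogen replaces phenyl on a saturated ring carbon; it shows how much the phenyl-bearing ring contributes.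

Compound 4 `CC(C)Cn1ccc(N2CCC(c3ccccc3)CC2)c(C#N)c1=O` keeps that ring and the shared core untouched and alters only the chain on the other side: isopropyl in place of isobutyl on a saturated chain carbon bound to an aromatic nitrogen. Neither measured step bears on this chain, since compound 2 and compound 3 both differ from compound 1 in the ring on the aromatic nitrogen's neighbour, not in the chain. There is therefore no measured guide to the size of the step, and the expectation rests on the change being small and remote from the part where the large step was seen.

The estimate for compound 4 is a modest increase, a 2.0-fold higher number from compound 1 to compound 4 (0.29 log units; within the scatter), with the number expected to be near 200 nM and likely to fall between 50 nM and 1000 nM.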

Compound 4, half-maximal effective concentration: 282 nM
For compound 4 the middle estimate is 1.4-fold (0.15 log units) below the measured one, and the stated range covers the measured number.
By their numbers in this assay, from the lowest: compound 1; then compound 4; then compound 3; then compound 2.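

In this assay the chain on the aromatic nitrogen now has a measured step of its own: going from isopentyl to isobutyl gives a 2.8-fold higher number from compound 1 to compound 4 (0.44 log units; beyond the scatter) and so shows that this position does respond to a small trim, even one far from the phenyl-bearing ring. The size of that step is modest beside a 310-fold higher number from compound 1 to compound 2 (2.49 log units; beyond the scatter) on the ring side, so among these compounds, removing the phenyl costs far more than shortening the chain. What lies behind the loss seen with the shorter chain remains unexplained, as no supporting measurement is available for this change.

The compounds shown explore this chain in the shorter direction only, so it remains open whether a longer chain, such as n-hexyl, or a chain ending in a cyclopropyl ring or a carboxylic acid would lower or raise the number. On these data alone, it is also open whether the same trim would give a step of similar size on the ring of compound 3, since the chain change has been paired with only the phenyl-bearing ring of compound 1.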